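A few compounds are considered here, and "the series" means these few. Any claim that something is new, unique, unknown or untested is made for them only; others in the source may bear on it.

Among the compounds with values here, compound 2 `Cc1nn(-c2ncnc3nc[nH]c23)c2c1C(C(=O)N(C)c1nccs1)CC(=O)N2` is the higher of the two numbers measured so far in a functional assay on HEK293 cells for agonist activity at G-protein coupled receptor 39 (Homo sapiens), read by scintillation proximity assay and inositol phosphate accumulation, with a stated time of 75 min, in the presence of a further agent that is not named here; on this read-out higher numbers stand for an effect only at larger amounts of compound and lower numbers for an effect already at smaller amounts: compound 2 gives 18 nM, while compound 1 `CCCCCCCCOC1CC(=O)Nc2c1c(C)nn2-c1ncnc2nc[nH]c12` gives 8 nM. Within the data shown here, the one measured step, a 2.3-fold higher number from compound 1 to compound 2 (0.35 log units; beyond the scatter), exchanged octyloxy for methyl(1,3-thiazol-2-yl)carbamoyl on the saturated ring carbon. Compound 3 `Cc1nn(-c2ncnc3nc[nH]c23)c2c1C(OCCc1ccccc1)CC(=O)N2` reverses that kind of exchange: phenethyloxy in place of methyl(1,3-thiazol-2-yl)carbamoyl on a saturated ring carbon. A new ether thus returns to the same place where the ether of compound 1 sat, though the chain now ends in a six-membered aromatic ring of carbon only rather than running on as eight carbons. Because compound 1 reached 8 nM with an ether at this position, a modest drop in the number is expected, of about a 1.8-fold lower number from compound 2 to compound 3 (0.26 log units; within the scatter) in this assay. Compound 3 is therefore estimated at 10 nM, with a likely range from 3 nM to 35 nM.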

Compound 3, half-maximal effective concentration: 3 nM
Compound 3: middle estimate off by 3.3-fold (0.52 log units), on the high side; the range from low to high includes it.
By their numbers in this assay, from the lowest: compound 3; then compound 1; then compound 2.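

In this assay, the ether is now favoured over the amide at this saturated ring carbon by more than one example: swapping methyl(1,3-thiazol-2-yl)carbamoyl for phenethyloxy, with the same count of heavy atoms entering as leaving, gives a 6.0-fold lower number from compound 2 to compound 3 (0.78 log units; beyond the scatter) in this comparison. The ether also need not run on as a long saturated chain, since phenyl in place of hexyl gives a 2.7-fold lower number from compound 1 to compound 3 (0.43 log units; beyond the scatter) with the oxygen kept where it was. Nothing measured here explains why either change lowers the number.

The compounds shown leave open whether the ether oxygen itself is needed, which a phenylpropyl group in its place would test. They also leave open how a shorter benzyloxy chain, or an amine or a carboxylic acid on the phenyl ring, would behave at this position.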